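A few compounds are considered here, and "the series" means these few. Any claim that something is new, unique, unknown or untested is made for them only; others in the source may bear on it.

Measured so far in an assay on membranes from HeLa cells for displacement of a labelled ligand from adenosine receptor A3 (Homo sapiens), read by scintillation counting, with a stated time of 180 min, tested at 1 uM; on this read-out lower numbers stand for less inhibition and higher numbers for more inhibition at the one concentration tested (going by the name of the read-out):

compound 1, `CCCOC(=O)C1=C(C)NC(=O)NC1c1ccoc1`: 11%
compound 2, `COC(=O)C1=C(C)N(C)C(=O)NC1c1ccoc1`: 7%

Both numbers sit low on the scale, and the two lie within the scatter of each other, so no order between compound 1 and compound 2 can be read from them. Compound 2 holds the lowest of the two numbers shown, with compound 1 the nearest neighbour a few points up but inside the scatter; in this assay compound 2 gives 7%.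

The next step goes from compound 2 to compound 3, `CCCOC(=O)C1=C(C)N(C)C(=O)NC1c1ccoc1`. The change is ethyl in place of hydrogen on a saturated chain carbon bound to an oxygen next to a carbonyl group. Compound 1 already carries the propoxycarbonyl group, while compound 2 carries the methoxycarbonyl group with the methyl on the ring nitrogen; compound 3 combines the propoxycarbonyl group with that ring methyl. Within the data shown here, no step between measured pairs is available to calibrate this, but since compound 1 and compound 2 agree within the scatter, nothing points to a shift beyond the scatter for compound 3 in this assay, in either direction.

Compound 3 is therefore estimated at 10%, with a likely range from 0% to 25%, the expected step being a number 3 percentage points higher from compound 2 to compound 3 (within the scatter).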

Compound 3, a percentage reported as inhibition, at one concentration (the size of the read-out at that concentration, not a potency): 16%
The estimate for compound 3 lay 6 percentage points below the measured number; low and high end bracket the measured number.
By their numbers in this assay, from the lowest: compounds 2, 1 and 3 (each within the scatter of the next).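

Methoxycarbonyl to propoxycarbonyl, read in this assay with the ring nitrogen methylated on both sides, comes to a number 9 percentage points higher from compound 2 to compound 3 (within the scatter). On this evidence, ethyl in place of hydrogen at this saturated chain carbon gives no shift that can be told from the scatter. The series also gains its first reading of methyl in place of hydrogen on an amide-type nitrogen in a ring, with the propoxycarbonyl group held constant: a number 5 percentage points higher from compound 1 to compound 3 (within the scatter), again no shift that can be told from the scatter. All three compounds stay low on the scale, and in this assay compound 3 gives 16% at the one concentration tested, so neither change shows a handle on this read-out so far.

Going by these compounds, it remains open whether a longer chain such as hexyl on the same oxygen, or a carboxylic acid in place of the whole ester, would give a number clear of the scatter. Also open, on these data alone, is whether a group larger than methyl on the ring nitrogen, such as benzyl, or one carrying an amine, would do so. No measurement at hand bears on why these numbers fall where they do.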